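A few compounds are considered here, and "the series" means these few. Any claim that something is new, unique, unknown or untested is made for them only; others in the source may bear on it.

In a functional assay on KB cells (Homo sapiens) for antiproliferative activity, read by sulforhodamine B assay, with a stated time of 3 days (on this read-out lower numbers stand for an effect already at smaller amounts and higher numbers for an effect only at larger amounts of compound), compound 3 `CCC1=C(O)c2c(oc(-c3ccccc3F)cc2=O)C(CC)(CC)C1=O` is known only as a limit (> 56.2 uM). Compound 1 `CCC1=C(O)c2c(oc(-c3ccccc3)cc2=O)C(CC)(CC)C1=O` is also only a limit (> 236 uM). Compound 2 `CCC1=C(O)c2c(oc(-c3cccc(C)c3)cc2=O)C(CC)(CC)C1=O` gives a number (49.7 uM). Compound 4 `CCC1=C(O)c2c(oc(-c3ccc(C)c(Cl)c3)cc2=O)C(CC)(CC)C1=O` carries 3-chloro-4-methylphenyl in place of 2-fluorophenyl on an aromatic carbon next to the ring oxygen (3-chloro-4-methylphenyl in place of 2-fluorophenyl on an aromatic carbon). For the measured compounds named here, three measured steps bear on this. Methyl in place of hydrogen gave an at least 4.7-fold lower number from compound 1 to compound 2 (0.67 log units; beyond the scatter). Fluoro in place of hydrogen gave a step that the two limits leave unreadable from compound 1 to compound 3. Replacing 3-methylphenyl with 2-fluorophenyl gave an at least 1.1-fold higher number from compound 2 to compound 3 (0.05 log units; that floor lies within the scatter). Compound 4 loses the fluoro and, like compound 2, bears a methyl on the phenyl, so the methyl step is the main guide. A modest move to a lower number is therefore expected (an at least 2.5-fold lower number from compound 3 to compound 4 (0.40 log units; beyond the scatter)). The estimate for compound 4 is 22 uM, with an expected range from 6 uM to 70 uM.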

Compound 4, concentration for half-maximal effect: 39 uM
For compound 4 the middle estimate is 1.8-fold (0.25 log units) below the measured one, and the stated range covers the measured number.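

In this assay compound 1 is only a limit: the limit of > 236 uM in this assay, at which 1 of the 4 values shown sits. Even so, 3-chloro-4-methylphenyl in place of phenyl gives an at least 6.0-fold lower number from compound 1 to compound 4 (0.78 log units; beyond the scatter), while in place of 3-methylphenyl it gives a 1.3-fold lower number from compound 2 to compound 4 (0.11 log units; within the scatter), so at this place next to the ring oxygen a second substituted phenyl keeps the gain seen with compound 2. Compound 3 is likewise only a limit, so an at least 1.4-fold lower number from compound 3 to compound 4 (0.15 log units; that floor lies within the scatter) is a floor that does not separate 2-fluorophenyl from 3-chloro-4-methylphenyl: the limit of > 56.2 uM in this assay, at which 1 of the 4 values shown sits.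

The compounds shown leave open whether the chloro or the methyl carries the step from phenyl. They also leave open how a phenyl bearing an amine or a carboxylic acid would read.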